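This account rests on a few compounds, and the source may have more. Where it says the series, first, only, none or still open, it means among the compounds named here.

Compound 1 `N#Cc1c(N)nc(SCC(N)=O)c(C#N)c1-c1ccc(OCC2CC2)cc1` gives 8% in an assay on CHO cells for displacement of a labelled ligand from adenosine receptor A3 (Homo sapiens), read by scintillation counting, with a stated time of 120 min, tested at 1 uM; on this read-out lower numbers stand for less inhibition and higher numbers for more inhibition at the one concentration tested (going by the name of the read-out).
Compound 2 `N#Cc1c(N)nc(SCc2ccn[nH]2)c(C#N)c1-c1ccc(OCC2CC2)cc1` gives 6% in this assay.
Compound 3 `N#Cc1c(N)nc(SCc2nnn[nH]2)c(C#N)c1-c1ccc(OCC2CC2)cc1` gives 1% in this assay.

On the numbers alone compound 3 stands lowest of the three, yet the two steps that end at it, a number 5 percentage points lower from compound 2 to compound 3 (within the scatter) and a number 7 percentage points lower from compound 1 to compound 3 (within the scatter), are both within the usual scatter, so the three compounds cannot be told apart in this assay. Compound 4 `N#Cc1c(N)nc(SCn2cncn2)c(C#N)c1-c1ccc(OCC2CC2)cc1` shares the core of compound 3 and differs from it in one place: 1H-1,2,4-triazol-1-yl in place of 1H-tetrazol-5-yl on a saturated chain carbon bound to a sulfur. All three measured steps swap the group on the saturated chain carbon bound to a sulfur, and each stayed within the scatter: a number 2 percentage points lower from compound 1 to compound 2 (within the scatter), a number 7 percentage points lower from compound 1 to compound 3 (within the scatter) and a number 5 percentage points lower from compound 2 to compound 3 (within the scatter). A further swap at the same place is therefore expected to bring no step beyond the scatter, and the expected change is a number 4 percentage points higher from compound 3 to compound 4 (within the scatter). Compound 4 is estimated at 5% in this assay, with a range from -6% to 16%.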

Compound 4, a percentage reported as inhibition, at one concentration (the size of the read-out at that concentration, not a potency): 1%
Compound 4: middle estimate off by 4 percentage points, on the high side, within the range that was stated.
By their numbers in this assay, from the lowest: compounds 3, 4, 2 and 1 (each within the scatter of the next).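

Compound 4 brings a new kind of group to the saturated chain carbon bound to a sulfur: 1H-1,2,4-triazol-1-yl has 0 hydrogen-bond donors where 1H-tetrazol-5-yl has 1 hydrogen-bond donor, and in this assay this swap gives no change at the digits printed from compound 3 to compound 4 (within the scatter). The comparisons with the other two groups read the same way, with a number 5 percentage points lower from compound 2 to compound 4 (within the scatter) and a number 7 percentage points lower from compound 1 to compound 4 (within the scatter), so in this assay all four groups at this position remain indistinguishable, whether or not the ring carries that donor. Nothing available here explains why these groups read alike.

Going by these compounds, whether an amine, a carboxylic acid or a longer chain on the saturated chain carbon bound to a sulfur would give a step beyond the scatter stays open. Also open, on these data alone, is whether a change elsewhere on the shared core would do so.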